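Swapping a phenyl group in a series at its limit

The compounds below may be only part of what the source reports. "The series", "measured", "known", "first", "only" and "open" are said of these compounds alone.

In an ADME assay on microsomes from liver (Rattus norvegicus) for metabolic stability (a higher number here means that the compound lasts longer, a lower number that the compound disappears faster), compound 1 `Nc1nc(NCCNc2ncc(-c3ncc[nH]3)c(-c3cc(F)c(F)cc3F)n2)ccc1[N+](=O)[O-]` gives > 0.5 h, which is a limit of the assay and not a number. Compound 2 `Nc1nc(NCCNc2ncc(-c3ncc[nH]3)c(-c3ccc(F)cc3Br)n2)ccc1[N+](=O)[O-]` gives > 0.5 h, again a limit. Compound 3 `Nc1nc(NCCNc2ncc(-c3ncc[nH]3)c(-c3ccc(F)cc3C(F)(F)F)n2)ccc1[N+](=O)[O-]` gives > 0.5 h, likewise a limit. Among the measured compounds shown here, the series so far therefore shows (the limit of > 0.5 h in this assay, at which 3 of the 3 values shown sit), and compound 3 has no exact half-life to start from.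

Compound 4 `Nc1nc(NCCNc2ncc(-c3ncc[nH]3)c(-c3ccc(Cl)cc3F)n2)ccc1[N+](=O)[O-]` carries 4-chloro-2-fluorophenyl in place of the 4-fluoro-2-(trifluoromethyl)phenyl of compound 3, on an aromatic carbon (4-chloro-2-fluorophenyl in place of 4-fluoro-2-(trifluoromethyl)phenyl on an aromatic carbon). Three measured steps change this same group: a step that the two limits leave unreadable from compound 1 to compound 2, a step that the two limits leave unreadable from compound 1 to compound 3 and a step that the two limits leave unreadable from compound 2 to compound 3. None of them has a size that can be read, so they offer no size or direction to carry over to the new change. The three compounds do all share the same reading, so compound 4 is expected to resemble them. No step beyond the usual scatter is expected, and the estimated step is a step that the limit leaves unreadable from compound 3 to compound 4. In this assay, compound 4 is expected to have a half-life of 0.7 h, with an estimated range from 0.4 h to 1.5 h.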

Compound 4, half-life: > 0.5 h
Compound 4: only a limit was reported; the forecaster's own chance of this, stated with the estimate: 80%; the middle value does not contradict the limit.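

Compound 4 gives > 0.5 h in this assay, which is a limit and not a number. None of the steps among compound 1, compound 2, compound 3 and compound 4 can be read, as all of them share one reading: the limit of > 0.5 h in this assay, at which 4 of the 4 values shown sit. How long each of these compounds actually lasts, and whether swapping the phenyl group changes that, remains open.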